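A few compounds are considered here, and "the series" means these few. Any claim that something is new, unique, unknown or untested is made for them only; others in the source may bear on it.

Measured compounds and their values:

Compound 1, `CC(=C\c1ccccc1)/C=C1\CCC=CC1=O`: 4800 nM
Compound 2, `Cc1ccc(/C=C/C=C2\CCC=CC2=O)cc1`: 7200 nM

The account follows the step from compound 2 to compound 3. In a functional assay on HCT-116 cells (Homo sapiens) for cytotoxicity, read by MTT assay, with a stated time of 72 h (on this read-out lower numbers stand for stronger inhibition and higher numbers for weaker inhibition), compound 2 gives 7200 nM, which is the higher of the two numbers recorded. Its nearest neighbour is compound 1, which in this assay gives 4800 nM; the gap between the two lies within the usual scatter of repeated measurements, so the two compounds are not distinguished by these data.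

Compound 3 is `CN(C)c1ccc(/C=C/C=C2\CCC=CC2=O)cc1`. It differs from compound 2 in one place: dimethylamino in place of methyl on an aromatic carbon. Within the data shown here, no step between two measured compounds bears on this change, so the expectation rests on the change itself and on where compound 2 stands. A modest step is expected, toward a lower number, of a size that may only just exceed the scatter: the step of a 2.4-fold lower number from compound 2 to compound 3 (0.38 log units; beyond the scatter) is the expected one.

For compound 3 the estimated value in this assay is 3000 nM, with a range from 1000 nM to 9000 nM.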

Compound 3, half-maximal inhibitory concentration: 1200 nM
The estimate for compound 3 lay 2.5-fold (0.40 log units) above the measured number; the range from low to high includes it.
By their numbers in this assay, from the lowest: compound 3; then compounds 1 and 2 (each within the scatter of the next).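

The change from methyl to dimethylamino on an aromatic carbon, para to a large group, gives a 6.0-fold lower number from compound 2 to compound 3 (0.78 log units; beyond the scatter) in this assay. Among these compounds, this shows that the read-out responds to the group at this position, something the earlier compounds could not show, as no step between measured compounds bore on it. The change replaces a group of 1 heavy atom and no hydrogen-bond acceptor with one of 3 heavy atoms and 1 hydrogen-bond acceptor, and no measurement here separates these differences or accounts for the lower number.

The compounds shown leave open whether the nitrogen or the size of the group matters more, a question that a primary amine, a methoxy group or a diethylamino group at the same position could help to address. They also leave open whether dimethylamino would give a step of similar size on the core of compound 1, and whether the step would hold in cells other than those tested here.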